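Carbamate variation in a lactam aldehyde series

This account rests on a few compounds, and the source may have more. Where it says the series, first, only, none or still open, it means among the compounds named here.

Measured so far:
compound 1 `CC(C)C[C@H](NC(=O)OC(c1ccccc1)C1CCC(F)(F)CC1)C(=O)N[C@H](C=O)C[C@@H]1CCNC1=O`: a limit of > 100000 nM in an ADME assay on HEK-293T cells (Homo sapiens) for cytotoxicity, with a stated time of 72 h (on this read-out higher numbers stand for lower toxicity in this test and lower numbers for higher toxicity in this test), not a number.
compound 2 `CC(C)C[C@H](NC(=O)OCc1cccc(F)c1)C(=O)N[C@H](C=O)C[C@@H]1CCNC1=O`: a limit of > 100000 nM in this assay, again not a number.

Compound 2 therefore stands at the same place as compound 1: the limit of > 100000 nM in this assay, at which 2 of the 2 values shown sit. Among the compounds with values here, neither measured compound gives a number, so no step between measured compounds can be stated, and no size of effect for any structural change is known from this pair.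

Compound 3 `CCCC(OC(=O)N[C@@H](CC(C)C)C(=O)N[C@H](C=O)C[C@@H]1CCNC1=O)c1ccccc1` differs from compound 2 by 1-phenylbutyl in place of 3-fluorobenzyl on an oxygen next to a carbonyl group.

Within the data shown here, with only two limits and no measured step, the expectation for compound 3 in this assay rests on compound 2 alone, since compound 2 shows only the limit > 100000 nM. No change beyond the scatter is expected for the step of a number no higher from compound 2 to compound 3 (the limit leaves the size open). Compound 3 is estimated at 100000 nM, with a range from 50000 nM to 200000 nM, most likely reported again only as a limit.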

Compound 3, half-maximal cytotoxic concentration: > 100000 nM
Compound 3 was reported as a limit (the forecaster's own chance of this, stated with the estimate: 75%); the middle value lies on the limit itself.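

No step from compound 1 or compound 2 to compound 3 can be read in this assay, since all three results are limits and not numbers: the limit of > 100000 nM in this assay, at which 3 of the 3 values shown sit.

The compounds shown leave open at what concentration, if any, cytotoxicity appears for any of them in this assay and whether the carbamate groups differ in effect.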